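Amino acid side chain exchanged: compound 3 to compound 4

A few compounds are considered here, and "the series" means these few. Any claim that something is new, unique, unknown or untested is made for them only; others in the source may bear on it.

Going by the values given here, compound 3 `N=C(N)NCCC[C@H](NC(=O)CN(c1nc(Cl)nc2[nH]cnc12)C1CC1)C(=O)O` stands highest of the three numbers so far; in a functional assay on the whole organism (Tail, strain ICR) with Mus musculus as the target, in the tail flick test, with a stated time of 30 min, at a dose of 12.5 umol/kg by the oral route (a higher number here means a stronger effect of the compound at the dose given, a lower number a weaker effect), compound 3 gives 22.2%. Compound 1 `NCCCC[C@H](NC(=O)CN(c1nc(Cl)nc2[nH]cnc12)C1CC1)C(=O)OCc1ccccc1` gives 18.5% and compound 2 `CC(C)[C@H](NC(=O)CN(c1nc(Cl)nc2[nH]cnc12)C1CC1)C(=O)OCc1ccccc1` gives 16%, both within the scatter of compound 3, so no order among the three can be claimed. Compound 4 `CC(C)C[C@H](NC(=O)CN(c1nc(Cl)nc2[nH]cnc12)C1CC1)C(=O)O` differs from compound 3 by a group of 3 heavy atoms (3 carbon; no ring) in place of a group of 6 heavy atoms (3 carbon, 3 nitrogen; no ring), on a saturated chain carbon, two bonds along the chain from an amide-type nitrogen and a carbonyl carbon. Among the compounds with values here, the one measured step that bears on this is a number 2.5 percentage points lower from compound 1 to compound 2 (within the scatter), the same kind of exchange of a nitrogen-bearing chain for a small alkyl group. From that step no move beyond the scatter is expected here. The estimated step is a number 3.2 percentage points lower from compound 3 to compound 4 (within the scatter). Compound 4 is therefore expected to give 19%, with a range from 8% to 30%.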

Compound 4, a percentage reported as activity, at one dose (the size of the read-out at that dose, not a potency): 16%
Compound 4: the middle estimate sits 3 percentage points above what was measured, within the range that was stated.
By their numbers in this assay, from the lowest: compounds 2, 4, 1 and 3 (each within the scatter of the next).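

In this assay the exchange also stays within the scatter on the free carboxylic acid: a number 6.2 percentage points lower from compound 3 to compound 4 (within the scatter) with isopropyl in place of the group of 6 heavy atoms and its 3 hydrogen-bond donors. The earlier step of a number 2.5 percentage points lower from compound 1 to compound 2 (within the scatter) came from benzyl esters, so this position now shows no separation in either form. Nothing at hand accounts for these flat numbers.

From the compounds shown here alone, whether a phenyl ring or a hydroxyl group at this position would move the number beyond the scatter stays open. Going by these compounds alone, the benzyl ester against the carboxylic acid with the same side chain also stays open, as no pair here differs in that place alone.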